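Chloro for Fluoro on the Pendant Phenyl Ring

The compounds below may be only part of what the source reports. "The series", "measured", "known", "first", "only" and "open" are said of these compounds alone.

Compound 1 `Cn1ccc2c(Oc3ccc(NC(=O)c4cn(-c5ccccc5)c5ccccc5c4=O)cc3F)ccnc21` — 2790 nM
Compound 2 `Cn1ccc2c(Oc3ccc(NC(=O)c4cn(-c5ccc(F)cc5)c5ccccc5c4=O)cc3F)ccnc21` — "not determined" (no result reported)

Compound 2 has no single number in a functional assay on MCF7 cells (Homo sapiens) for inhibition, read by MTT assay, with a stated time of 72 h; a lower number here means a stronger inhibitor, a higher number a weaker inhibitor; its entry reads "not determined" (no result reported). Among the measured compounds shown here, the only measured anchor is compound 1, which in this assay gives 2790 nM. Compound 3 `Cn1ccc2c(Oc3ccc(NC(=O)c4cn(-c5ccc(Cl)cc5)c5ccccc5c4=O)cc3F)ccnc21` differs from compound 2 by chloro in place of fluoro on an aromatic carbon. For the measured compounds named here, no step between measured compounds exists here, so any expectation rests on compound 1 alone; a change of this kind is expected to stay within the usual scatter, with no clear direction. Compound 3 is therefore expected to give about 2500 nM, between 700 nM and 9000 nM.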

Compound 3, half-maximal inhibitory concentration: 2120 nM
Beside the measured number, compound 3's estimate is 1.2-fold (0.07 log units) above it, within the range that was stated.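

Putting chloro in place of hydrogen on this aromatic carbon gives a 1.3-fold lower number from compound 1 to compound 3 (0.12 log units; within the scatter) in this assay, so the position takes a chloro group with no clear gain or loss of activity. Compound 2 carries no number, and the change from 4-fluorophenyl to 4-chlorophenyl itself cannot be read. Nothing shown accounts for this result.

Going by these compounds, whether a larger change here, such as an amine or a carboxylic acid on the same carbon, would move the number beyond the scatter stays open. A single chloro group cannot show how far this position tolerates change.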